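Exchanging the aromatic group of compound 1

The compounds below may be only part of what the source reports. "The series", "measured", "known", "first", "only" and "open" are said of these compounds alone.

For the measured compounds named here, in a functional assay on WM164 cells (Homo sapiens) for antiproliferative activity, read by sulforhodamine B assay, with a stated time of 48 h (on this read-out lower numbers stand for stronger inhibition and higher numbers for weaker inhibition), compound 1 (`CCCCCCCCCCCCNC(=O)[C@@H]1CSC(c2ccc(OC)c(OC)c2)N1`) gives 1600 nM as the higher of the two numbers so far, and compound 2 (`CCCCCCCCCCCCCCCCNC(=O)[C@@H]1CSC(c2ccc(OC)c(OC)c2)N1`) gives 500 nM with its longer chain. Compound 3 (`CCCCCCCCCCCCNC(=O)[C@@H]1CSC(c2ccc(NC(C)=O)cc2)N1`) keeps the chain of compound 1 but carries 4-acetamidophenyl in place of 3,4-dimethoxyphenyl on a saturated ring carbon. Going by the values given here, the only measured step (a 3.2-fold lower number from compound 1 to compound 2 (0.51 log units; beyond the scatter)) changes the chain and not this group, so it offers no direct guide. The expected step (a 1.3-fold higher number from compound 1 to compound 3 (0.10 log units; within the scatter)) therefore stays within the scatter, with no clear direction. Compound 3 is estimated at 2000 nM with an expected range of 700 nM to 6000 nM in this test.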

Compound 3, half-maximal inhibitory concentration: 1200 nM
Compound 3: middle estimate off by 1.7-fold (0.22 log units), on the high side; the range from low to high includes it.
By their numbers in this assay, from the lowest: compound 2; then compounds 3 and 1 (each within the scatter of the next).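

Placing 4-acetamidophenyl instead of 3,4-dimethoxyphenyl on this saturated ring carbon gives a 1.3-fold lower number from compound 1 to compound 3 (0.12 log units; within the scatter) in this assay. This position therefore takes a group with a hydrogen-bond donor, absent from 3,4-dimethoxyphenyl, without a difference beyond the scatter. No other measurement here helps to interpret this result. On these data alone, whether an amine or a carboxylic acid in place of the acetamido group would read the same remains open. So does whether 4-acetamidophenyl would read the same alongside the longer chain of compound 2.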